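Trifluoromethoxy for trifluoromethyl: expected clearance of compound 4

The source may hold more compounds than are shown below. What is called first, only, known or untested is meant among the compounds shown, and "the series" means these compounds.

- compound 1 `C[C@]1(O)C[C@](c2cccc(OC(F)(F)F)c2)([C@H](O)c2ccccn2)C1`: 117 mL/min/kg
- compound 2 `O[C@H](c1ccccn1)[C@]1(c2cccc(OC(F)(F)F)c2)C[C@@H](O)C1`: 117 mL/min/kg
- compound 3 `C[C@]1(O)C[C@@](c2cccc(C(F)(F)F)c2)([C@H](O)c2ccccn2)C1`: 150 mL/min/kg
- compound 4 `C[C@]1(O)C[C@@](c2cccc(OC(F)(F)F)c2)([C@H](O)c2ccccn2)C1`: not yet measured

In an ADME assay on liver for metabolic stability, with Liver microsome (Homo sapiens) as the target, read by LC-MS, using microsomes, with a stated time of 5 h (on this read-out higher numbers stand for fast clearance and lower numbers for slow clearance), compound 3 gives 150 mL/min/kg, within the scatter of the other two measured values. Compound 4 carries trifluoromethoxy in place of trifluoromethyl on an aromatic carbon, meta to a large group: trifluoromethoxy in place of trifluoromethyl on an aromatic carbon. Among the measured compounds shown here, no measured pair isolates this change. The trifluoromethoxy compounds offer only indirect guidance, with compound 1 at 117 mL/min/kg and compound 2 at 117 mL/min/kg, so no step beyond the scatter is expected in this assay. The estimated step, a 1.2-fold lower number from compound 3 to compound 4 (0.08 log units; within the scatter), remains within the scatter. For compound 4 the estimated value is 125 mL/min/kg, with an expected range of 75 mL/min/kg to 200 mL/min/kg.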

Compound 4, clearance: 167 mL/min/kg
Beside the measured number, compound 4's estimate is 1.3-fold (0.13 log units) below it, within the range that was stated.
By their numbers in this assay, from the lowest: compounds 1, 2, 3 and 4 (each within the scatter of the next).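

In this assay, among the compounds shown here, trifluoromethoxy in place of trifluoromethyl on an aromatic carbon, meta to a large group, gives a 1.1-fold higher number from compound 3 to compound 4 (0.05 log units; within the scatter), the first direct reading of this change, and it stays within the scatter. Methyl in place of hydrogen on a saturated ring carbon gives a 1.4-fold higher number from compound 2 to compound 4 (0.15 log units; within the scatter), also within the scatter. The change in configuration as drawn gives a 1.4-fold higher number from compound 1 to compound 4 (0.15 log units; within the scatter), again within the scatter, and this pair isolates configuration alone: the fact that compounds 1 and 4 differ only in the configuration as drawn. As far as these compounds go, whether an amine or a carboxylic acid on that aromatic carbon would move clearance beyond the scatter remains open.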